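The source may report more compounds than this note shows. Statements on the series, on what has been measured and on what is new or still open speak of the compounds shown alone.

Measured compounds in a functional assay on PC-3 cells (Homo sapiens) for cytotoxicity, read by MTT assay, with a stated time of 72 h; a higher number here means a weaker inhibitor, a lower number a stronger inhibitor:
compound 1 `FC(F)(F)c1ccc(CSc2nc(N3CCCCC3)c3ccccc3n2)cc1` gives 25500 nM
compound 2 `FC(F)(F)c1ccc(CSc2nc(Nc3cccc(Br)c3)c3ccccc3n2)cc1` gives 8680 nM
compound 3 `FC(F)(F)c1ccc(CSc2nc(Nc3ccc(C(F)(F)F)cc3)c3ccccc3n2)cc1` gives 7880 nM

Compound 3 has the lowest number of the three, but the step of a 1.1-fold lower number from compound 2 to compound 3 (0.04 log units; within the scatter) is within the scatter, so compound 2 and compound 3 are not separated. Both stand apart from compound 1: a 2.9-fold lower number from compound 1 to compound 2 (0.47 log units; beyond the scatter) and a 3.2-fold lower number from compound 1 to compound 3 (0.51 log units; beyond the scatter). The change that matters in this assay is therefore the arylamino in place of piperidin-1-yl; exchanging the substituent on the arylamino ring, 3-bromophenyl for 4-(trifluoromethyl)phenyl, did not move the number beyond the scatter.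

Compound 4 `Cc1ccc(Nc2nc(SCc3ccc(C(F)(F)F)cc3)nc3ccccc23)cc1` differs from compound 3 only by methyl in place of trifluoromethyl on an aromatic carbon. Among the compounds with values here, no measured step covers this exact exchange; the nearest precedent is the substituent swap from compound 2 to compound 3 on the same ring, which stayed within the scatter. The arylamino group is retained. The expected step of a 1.1-fold higher number from compound 3 to compound 4 (0.06 log units; within the scatter) is accordingly small and not beyond the scatter. Compound 4 is estimated at 9000 nM in this assay, within 4000 nM to 22000 nM.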

Compound 4, half-maximal inhibitory concentration: 21100 nM
Compound 4: middle estimate off by 2.3-fold (0.37 log units), on the low side; measured number inside the range.
By their numbers in this assay, from the lowest: compounds 3 and 2 (each within the scatter of the next); then compounds 4 and 1 (each within the scatter of the next).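

In this assay, the substituent on the arylamino ring now counts: methyl in place of trifluoromethyl gives a 2.7-fold higher number from compound 3 to compound 4 (0.43 log units; beyond the scatter), and 4-methylphenyl in place of 3-bromophenyl gives a 2.4-fold higher number from compound 2 to compound 4 (0.39 log units; beyond the scatter), whereas the earlier exchange on this ring stayed within the scatter. The arylamino group alone therefore does not secure the lower numbers seen for compound 2 and compound 3: compound 4 goes against that reading, with (4-methylphenyl)amino in place of piperidin-1-yl giving only a 1.2-fold lower number from compound 1 to compound 4 (0.08 log units; within the scatter). No measured evidence accounts for the difference between methyl and trifluoromethyl at this position.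

Open, on these data alone, is how a methoxy group, a nitrile or an amine on this aromatic carbon would read. Also open, as far as these compounds go, is whether a halogen such as chlorine here would stay with trifluoromethyl or with methyl.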